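Extending a Pentyl Side Chain by One Carbon

The compounds below may be only part of what the source reports. "The series", "measured", "known", "first", "only" and "open" are said of these compounds alone.

Measured compounds in a functional assay on L1210 cells (Mus musculus) for cytotoxicity; on this read-out higher numbers stand for an effect only at larger amounts of compound and lower numbers for an effect already at smaller amounts:
- Compound 1, `COc1cc(CO)c(OC)c2c1C(=O)C=CC2=O`, gives 0.062 ug/mL
- Compound 2, `CCCCCC(O)c1cc(OC)c2c(c1OC)C(=O)C=CC2=O`, gives 0.066 ug/mL
- Compound 3, `COc1ccc(OC)c2c1C(=O)C=C(CO)C2=O`, gives 0.524 ug/mL

Compound 2 stands second highest of the three numbers in this assay. Its nearest neighbour is compound 1, whose value lies within the usual scatter of repeated measurements, so the two cannot be told apart. Compound 3 lies furthest away, with a number that differs beyond the scatter.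

The compound not yet measured is compound 4, `CCCCCCC(O)c1cc(OC)c2c(c1OC)C(=O)C=CC2=O`. It differs from compound 2 only by methyl in place of hydrogen on a saturated chain carbon, six bonds along the chain from an aromatic carbon and an oxygen on a saturated carbon, a step that extends the pentyl chain of compound 2 by one carbon.

For the measured compounds named here, one measured step bears on this: a 1.1-fold higher number from compound 1 to compound 2 (0.03 log units; within the scatter). Putting a whole pentyl chain onto the saturated carbon bearing the hydroxyl did not move the number beyond the scatter. Adding one more carbon to that chain is a smaller change of the same kind, so no step beyond the scatter is expected, in either direction.

Compound 4 is therefore expected to give about 0.07 ug/mL in this assay, with a plausible range from 0.03 ug/mL to 0.16 ug/mL. That estimate corresponds to the step of a 1.1-fold higher number from compound 2 to compound 4 (0.03 log units; within the scatter).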

Compound 4, concentration for half-maximal effect: 0.22 ug/mL
For compound 4 the middle estimate is 3.1-fold (0.50 log units) below the measured one; the measured number lies above the stated range.
By their numbers in this assay, from the lowest: compounds 1 and 2 (each within the scatter of the next); then compound 4; then compound 3.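

In this assay, the length of the chain on the saturated carbon bearing the hydroxyl does matter, even though the first step, a 1.1-fold higher number from compound 1 to compound 2 (0.03 log units; within the scatter), gave no sign of it. Methyl in place of hydrogen on a saturated chain carbon, six bonds along the chain, gives a 3.3-fold higher number from compound 2 to compound 4 (0.52 log units; beyond the scatter) and so a small addition moves the number beyond the scatter where a whole pentyl did not. Hexyl in place of hydrogen on the carbon bearing the hydroxyl gives a 3.5-fold higher number from compound 1 to compound 4 (0.55 log units; beyond the scatter) and so a larger amount of compound is needed for the effect, but nothing available here explains this change in cytotoxicity.

As far as these compounds go, whether a longer chain such as heptyl or octyl raises the number further or levels off remains open. So does how a shorter chain such as propyl or butyl behaves, and whether an amine on the chain would change the picture.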